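A few compounds are considered here, and "the series" means these few. Any claim that something is new, unique, unknown or untested is made for them only; others in the source may bear on it.

Measured compounds in the series:

compound 1 `Cn1c(CN2CCN(c3nc(Cl)ccc3C(F)(F)F)CC2)nc2cc(C#N)ccc21` — 50.1 nM
compound 2 `Cn1c(CN2CCN(c3nc(Cl)ccc3C(F)(F)F)CC2)nc2cc(C(F)(F)F)ccc21` — 2000 nM
compound 3 `Cn1c(CN2CCC(c3ccccc3)CC2)nc2ccccc21` — 200 nM

All three were read in an assay on CHO cells with metabotropic glutamate receptor 2 (Homo sapiens) as the target, read by FLIPR; on this read-out lower numbers stand for an effect already at smaller amounts and higher numbers for an effect only at larger amounts of compound. Within these three numbers compound 3 stands second highest: its nearest neighbour is compound 1, whose number is lower, and its furthest is compound 2, whose number is higher. Within the data shown here, the only single-point step measured so far is a 40-fold higher number from compound 1 to compound 2 (1.60 log units; beyond the scatter); it concerns a different ring and a different pair of groups than the change now in question, so it gives no direct guidance for compound 4 beyond showing that a swap on an aromatic carbon can move the read-out strongly.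

Compound 4 `Cn1c(CN2CCC(c3ccccc3F)CC2)nc2ccccc21` differs from compound 3 as follows: fluoro in place of hydrogen on an aromatic carbon. Among the measured compounds shown here, no measured pair shows this exchange, and nothing shows how the shared core of compound 3 and compound 4 responds to a change on the phenyl ring. For the measured compounds named here, the expectation therefore rests on compound 3 alone, with a single fluorine entering as the only change, and the default is a step of no more than the usual scatter in either direction.

On that basis compound 4 is expected to give 200 nM in this assay, with a likely range from 60 nM to 650 nM. The step this implies is estimated as no change at the digits printed from compound 3 to compound 4 (within the scatter).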

Compound 4, half-maximal effective concentration: 126 nM
The estimate for compound 4 lay 1.6-fold (0.20 log units) above the measured number; measured number inside the range.
By their numbers in this assay, from the lowest: compound 1; then compounds 4 and 3 (each within the scatter of the next); then compound 2.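

In this assay, among these compounds, the change from phenyl to 2-fluorophenyl gives a 1.6-fold lower number from compound 3 to compound 4 (0.20 log units; within the scatter), so fluoro in place of hydrogen at this carbon, ortho to a large group, produces no step that can be told from the scatter. Among the compounds shown here, this is the first reading of how the core shared by compound 3 and compound 4 responds to a change on its phenyl ring, and it shows that a single fluorine is tolerated at this position in this assay. It also shows that an exchange on an aromatic carbon need not have an effect of the size seen in a 40-fold higher number from compound 1 to compound 2 (1.60 log units; beyond the scatter), although that step involves another group on another core. No measurement available here bears on why the fluorine leaves the read-out within the scatter.

Still open, going by these compounds, is whether this position accepts anything larger or of a different kind than fluoro, such as chloro, methoxy, an amine or a carboxylic acid, and whether any of these would give a step beyond the scatter. Also open, on these data alone, is whether fluoro on other carbons of the phenyl ring behaves as it does here.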